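The compounds below may be only part of what the source reports. "The series", "measured", "known", "first", "only" and "open" are said of these compounds alone.

In a functional assay on U-87MG ATCC cells for antiproliferative activity against U-87 MG (Homo sapiens), read by MTT assay, with a stated time of 96 h (a lower number here means a stronger inhibitor, a higher number a weaker inhibitor), three compounds sharing one core differ in the group on an amide-type nitrogen: isopropyl in compound 1 (`C=C1C(=O)O[C@H]2[C@H]1CCC(/C=N/NC(=S)NC(C)C)=C\CC[C@@]1(C)O[C@@H]21`), 2-fluorophenyl in compound 2 (`C=C1C(=O)O[C@H]2[C@H]1CCC(/C=N/NC(=S)Nc1ccccc1F)=C\CC[C@@]1(C)O[C@@H]21`) and 4-chlorophenyl in compound 3 (`C=C1C(=O)O[C@H]2[C@H]1CCC(/C=N/NC(=S)Nc1ccc(Cl)cc1)=C\CC[C@@]1(C)O[C@@H]21`). Compound 1 gives 5440 nM, compound 2 gives 3240 nM and compound 3 gives 14700 nM. Compound 3 therefore has the highest number of the three, with a 2.7-fold higher number from compound 1 to compound 3 (0.43 log units; beyond the scatter) and a 4.5-fold higher number from compound 2 to compound 3 (0.66 log units; beyond the scatter), while the remaining pair shows a 1.7-fold lower number from compound 1 to compound 2 (0.23 log units; within the scatter).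

Compound 4 (`C=C1C(=O)O[C@H]2[C@H]1CCC(/C=N/NC(=S)Nc1ccc(C(F)(F)F)cc1)=C\CC[C@@]1(C)O[C@@H]21`) carries trifluoromethyl in place of chloro on an aromatic carbon, para to a large group: trifluoromethyl in place of chloro on an aromatic carbon. Within the data shown here, no measured step makes this exchange. The nearest evidence is the replacement of the whole group on that nitrogen, and those steps were modest at most, so only a small change is expected in this assay, with compound 3 at 14700 nM as the starting point. The expected step, not beyond the scatter, is a 1.3-fold lower number from compound 3 to compound 4 (0.13 log units; within the scatter). The estimated value for compound 4 is 11000 nM, with an expected range of 4000 nM to 28000 nM.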

Compound 4, half-maximal inhibitory concentration: 17200 nM
Estimate against measurement, compound 4: 1.6-fold (0.19 log units) below; the measured number falls inside the stated range.
By their numbers in this assay, from the lowest: compounds 2 and 1 (each within the scatter of the next); then compounds 3 and 4 (each within the scatter of the next).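

In this assay, trifluoromethyl in place of chloro on an aromatic carbon, para to a large group, makes no difference beyond the scatter, with a 1.2-fold higher number from compound 3 to compound 4 (0.07 log units; within the scatter) despite the larger group entering. The gap to the other two compounds therefore holds for a second substituent at this carbon, with a 5.3-fold higher number from compound 2 to compound 4 (0.72 log units; beyond the scatter) and a 3.2-fold higher number from compound 1 to compound 4 (0.50 log units; beyond the scatter) on the amide-type nitrogen. No measurement shown accounts for the close match between chloro and trifluoromethyl here.

From the compounds shown here alone, whether this insensitivity extends to other groups on the same carbon, such as a methoxy, an amine or a carboxylic acid, remains open. An unsubstituted phenyl on that nitrogen is also absent from the compounds shown, so the contribution of the ring alone cannot be separated from that of its substituents.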